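The source may report more compounds than this note shows. Statements on the series, on what has been measured and on what is new or still open speak of the compounds shown alone.

Of the compounds shown here, three built on a shared core have been tested in a functional assay on HEp-2 cells (Homo sapiens) for antiproliferative activity, read by MTT assay, with a stated time of 72 h; a higher number here means a weaker inhibitor, a lower number a stronger inhibitor. Compound 1 `Cc1ccc2c(=O)c(CSC(=S)N(C(C)C)C(C)C)coc2c1` gives 700 nM. Compound 2 `O=c1cc(CSC(=S)N2CCCCC2)oc2cc(Cl)ccc12` gives 1600 nM. Compound 3 `O=c1c(CSC(=S)N2CCCCC2)coc2cc(Cl)ccc12` gives 280 nM, the lowest of the three numbers; its gap to compound 1 and its larger gap to compound 2 both lie beyond the usual scatter, so compound 3 is the strongest inhibitor of the set.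

The next compound, compound 4 `O=c1c(CSC(=S)N2CCOCC2)coc2cc(Cl)ccc12`, has not yet been measured in this assay. It differs from compound 3 in one place: morpholin-4-yl in place of piperidin-1-yl on a thiocarbonyl carbon

Within the data shown here, no pair of measured compounds shows this exact change, so there is no measured step to lean on. The expectation is that this swap moves the number only a little, if at all. The step of a 1.4-fold higher number from compound 3 to compound 4 (0.15 log units; within the scatter) is expected to stay within the scatter, leaning slightly toward a weaker inhibitor. Compound 4 is therefore estimated at 400 nM, with a range from 150 nM to 1200 nM.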

Compound 4, half-maximal inhibitory concentration: 900 nM
Estimate against measurement, compound 4: 2.3-fold (0.35 log units) below; measured number inside the range.
By their numbers in this assay, from the lowest: compound 3; then compounds 1, 4 and 2 (each within the scatter of the next, the first and the last beyond it).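

In this assay, among these compounds, morpholin-4-yl in place of piperidin-1-yl on a thiocarbonyl carbon gives a 3.2-fold higher number from compound 3 to compound 4 (0.51 log units; beyond the scatter) and so a weaker inhibitor; the earlier compounds could not show this, as no two of them differ in one place only. The two rings have the same number of heavy atoms, and the entering ring holds an oxygen and one hydrogen-bond acceptor where the leaving ring has a carbon and none, so a small exchange at this place is enough to move the number beyond the scatter. Nothing shown here explains the step.

As far as these compounds go, whether the step belongs to the ring oxygen itself stays open, and thiomorpholin-4-yl, piperazin-1-yl or an open diethylamino group on the same carbon would help to separate these possibilities. Whether the same swap moves the number equally on the cores of compound 1 and compound 2 is also unknown.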